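This account rests on a few compounds, and the source may have more. Where it says the series, first, only, none or still open, it means among the compounds named here.

Measured so far:
compound 1, `O=C(Nc1cccc(-n2cc(-c3ccncc3)c(-c3ccc(Cl)c(O)c3)n2)c1)Nc1ccc(Cl)c(Cl)c1`, 570 nM
compound 2, `COc1cc(-c2nn(-c3cccc(NC(=O)c4ccc(Cl)c(C(F)(F)F)c4)c3)cc2-c2ccncc2)ccc1Cl`, 1380 nM

In a functional assay on SK-MEL-5 cells (Homo sapiens) for inhibition, read by sulforhodamine B assay, with a stated time of 48 h (a higher number here means a weaker inhibitor of growth, a lower number a stronger inhibitor of growth), compound 2 gives 1380 nM, the higher of the two numbers, while compound 1 gives 570 nM, a gap beyond the usual scatter. Compound 3, `COc1cc(-c2nn(-c3cccc(NC(=O)c4cccc(C(F)(F)F)c4)c3)cc2-c2ccncc2)ccc1Cl`, has not yet been measured. It differs from compound 2 by a single change: hydrogen in place of chloro on an aromatic carbon. Within the data shown here, no measured pair shows this change, so its effect here is unknown. The step of a 1.4-fold higher number from compound 2 to compound 3 (0.16 log units; within the scatter) is expected to be small, toward a weaker inhibitor, or nothing beyond the scatter. Compound 3 is therefore estimated at 2000 nM, within 700 nM to 6000 nM.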

Compound 3, concentration for 50% growth inhibition: 978 nM
Beside the measured number, compound 3's estimate is 2.0-fold (0.31 log units) above it; measured number inside the range.
By their numbers in this assay, from the lowest: compounds 1, 3 and 2 (each within the scatter of the next, the first and the last beyond it).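

Among these compounds, replacing chloro with hydrogen on the 4-chloro-3-(trifluoromethyl)phenyl group gives in this assay a step of a 1.4-fold lower number from compound 2 to compound 3 (0.15 log units; within the scatter) and provides the first measured reading of this change. In this one pair, the chloro at this position is not needed to keep growth inhibition at the level seen with compound 2. Nothing available here explains this result.
Still open, on these data alone, is whether an amine or a carboxylic acid at this position would shift the number beyond the scatter. The same question stands for removing the trifluoromethyl group.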